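Second benzyl on the ring nitrogen: expected growth inhibition

This account rests on a few compounds, and the source may have more. Where it says the series, first, only, none or still open, it means among the compounds named here.

Measured in a functional assay on A549 cells (Homo sapiens) for antiproliferative activity, read by MTT assay, with a stated time of 72 h; a higher number here means a weaker inhibitor of growth, a lower number a stronger inhibitor of growth:
compound 1 `Cc1ccc2nc(-c3ccc(N)cc3)cn2c1` gives only a limit, > 100000 nM.
compound 2 `Cc1ccc2nc(-c3ccc(NCc4ccccc4)cc3)cn2c1` gives 56100 nM.

Among the measured compounds shown here, compound 2 carries the only number in this assay; the other value, from compound 1, is a limit. Compound 3 `Cc1ccc2nc(-c3ccc(N(Cc4ccccc4)Cc4ccccc4)cc3)cn2c1` differs from compound 2 by benzyl in place of hydrogen on a nitrogen on an aromatic ring, a second benzyl on the same nitrogen. For the measured compounds named here, the only measured step of related kind is an at least 1.7-fold lower number from compound 1 to compound 2 (0.25 log units; that floor lies within the scatter); its size cannot be fixed because one end sits at the limit of > 100000 nM in this assay, at which 1 of the 2 values shown sits, and its floor lies within the scatter. Going by the values given here, no measured step covers a second benzyl on an already benzylated nitrogen. The step expected here, a 1.4-fold lower number from compound 2 to compound 3 (0.15 log units; within the scatter), is therefore small and may be no larger than the scatter, leaning if anything toward a lower number. Compound 3 in this assay is estimated at 40000 nM, with a range from 10000 nM to 100000 nM.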

Compound 3, concentration for 50% growth inhibition: 60000 nM
Compound 3: middle estimate off by 1.5-fold (0.18 log units), on the low side; the measured number falls inside the stated range.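

In this assay, the step for the second benzyl on this nitrogen is a 1.1-fold higher number from compound 2 to compound 3 (0.03 log units; within the scatter). Among the compounds shown here, this is the first step with a readable size, and it shows that compound 2 and compound 3 cannot be told apart: replacing the remaining hydrogen on this nitrogen with benzyl brings no change beyond the scatter. The earlier step could not show this, since compound 1 gives only a limit and the size of its step cannot be read: the limit of > 100000 nM in this assay, at which 1 of the 3 values shown sits.

As far as these compounds go, whether a different group on this nitrogen, such as a longer alkyl chain, an acetyl amide or a benzyl carrying a carboxylic acid, would move the number beyond the scatter remains open. Also open, from the compounds shown here alone, is whether any change to the shared core would do so.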